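The source may report more compounds than this note shows. Statements on the series, on what has been measured and on what is new or still open speak of the compounds shown alone.

- compound 1 `Cc1cc(C)c(CNC(=O)c2cccc(OC(C)C)c2C)c(=O)[nH]1` at 2.1 measured
- compound 2 `Cc1cc(C)c(CNC(=O)c2cccc(OC(C)C)c2Cl)c(=O)[nH]1` at 2 measured

Both numbers come from a physicochemical assay for lipophilicity, at pH 7.4 (on this read-out lower numbers stand for lower lipophilicity and higher numbers for higher lipophilicity), and are the only two available so far. Among the compounds with values here, compound 1 has no clear place above or below its one neighbour, the sole measured step being a number 0.10 log units lower from compound 1 to compound 2 (within the scatter) on this scale.

The unmeasured compound 3 `CCOc1cccc(C(=O)NCc2c(C)cc(C)[nH]c2=O)c1C` turns isopropoxy into ethoxy (hydrogen in place of methyl on a saturated chain carbon bound to an oxygen on an aromatic ring and a saturated chain carbon). Within the data shown here, the one measured step swaps chloro for methyl at a different place, so no measurement touches this chain directly, and the expectation rests on the structural change alone. A small downward move in this assay is expected (a number 0.35 log units lower from compound 1 to compound 3 (beyond the scatter)), and it may end up not far beyond the scatter. Compound 3 is expected at 1.75 (estimated range 1.4 to 2.1).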

Compound 3, distribution coefficient: 2.1
Compound 3: middle estimate off by 0.35 log units, on the low side; the measured number falls inside the stated range.
By their numbers in this assay, from the lowest: compounds 2, 1 and 3 (each within the scatter of the next).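

Going from isopropoxy to ethoxy gives no change at the digits printed from compound 1 to compound 3 (within the scatter) in this assay, the first reading at this chain, since the earlier step swapped chloro for methyl at a different place. At this saturated chain carbon, then, losing a single methyl leaves a difference that this small set cannot separate from the ordinary spread of repeated measurements. Nothing available bears on why the two compounds read alike, so the result stands as an observation without an explanation.

As far as these compounds go, a single carbon is a small change, so it remains open whether a longer chain such as butoxy would stand apart from compound 1 in this assay. From the compounds shown here alone, it is also open what a more drastic replacement at this place, such as a chain ending in an amine or a carboxylic acid, would do to the number.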